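A few compounds are considered here, and "the series" means these few. Any claim that something is new, unique, unknown or untested is made for them only; others in the source may bear on it.

Compound 1 `NC(=O)c1ccc(-c2ccc(Cl)cc2COc2ccc(-c3nc4cc(C(=O)O)ccc4n3C3CCCCC3)cc2)cc1`: > 50000 nM
Compound 2 `COc1ccc(-c2ccc(Cl)cc2)c(COc2ccc(-c3nc4cc(C(=O)O)ccc4n3C3CCCCC3)cc2)c1`: 24000 nM

Both entries come from a functional assay on Huh-5-2 cells (Homo sapiens), read by MTT assay; a higher number here means that more compound is tolerated, a lower number that less compound is tolerated. The entry for compound 1 is a limit of the assay and not a number. For the measured compounds named here, compound 2, at 24000 nM, therefore provides the only true number so far, so there is no measured series against which to rank it.

Compound 3 `CN(C)c1ccc(-c2ccc(Cl)cc2)c(COc2ccc(-c3nc4cc(C(=O)O)ccc4n3C3CCCCC3)cc2)c1` differs from compound 2 in one place, with dimethylamino in place of methoxy on an aromatic carbon. That carbon is meta to a large group and para to a 4-chlorophenyl group (dimethylamino in place of methoxy on an aromatic carbon). The rest of the molecule stays the same.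

Going by the values given here, no measured pair shows what this kind of swap does in this assay, so the expectation has little to rest on beyond compound 2 at 24000 nM. Among the compounds with values here, with only this one group changing, no shift beyond the usual scatter is expected in either direction, and the estimated 1.2-fold lower number from compound 2 to compound 3 (0.08 log units; within the scatter) is small. For compound 3 the expected half-maximal cytotoxic concentration is 20000 nM, with an estimated range of 8000 nM to 50000 nM.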

Compound 3, half-maximal cytotoxic concentration: 30000 nM
Beside the measured number, compound 3's estimate is 1.5-fold (0.18 log units) below it; measured number inside the range.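

For the compounds shown here, this is the first pair that differs in one place, and in this assay dimethylamino in place of methoxy gives a 1.3-fold higher number from compound 2 to compound 3 (0.10 log units; within the scatter). At this aromatic carbon, para to a 4-chlorophenyl group, the two groups therefore cannot be told apart in this read-out, so exchanging the oxygen-linked group for the nitrogen-linked one leaves no measurable mark on how much compound the cells tolerate. The assay also has an upper end, which limits how far any later gain in tolerance at this position could be read as a number: the limit of > 50000 nM in this assay, at which 1 of the 3 values shown sits.

Still open, on these data alone, is whether this carbon accepts other groups as readily, for example a primary amine, a hydroxyl group, a fluorine atom or a longer alkoxy chain, or whether one of these would move the number beyond the usual scatter. A single pair also cannot say whether the same exchange would give the same result at another carbon of this ring, or with a different group in place of the 4-chlorophenyl group.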